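A few compounds are considered here, and "the series" means these few. Any claim that something is new, unique, unknown or untested is made for them only; others in the source may bear on it.

Measured compounds:
- Compound 1 `COc1ccc(C(=O)N2N=C(c3ccccc3)CC2c2cn(C)c3ccccc23)cn1` gives > 300000 nM in an ADME assay on HEK-293T cells (Homo sapiens) for cytotoxicity, read by MTT assay, with a stated time of 48 h; on this read-out higher numbers stand for lower toxicity in this test and lower numbers for higher toxicity in this test; this is a limit of the assay, not a number.
- Compound 2 `Cc1ccc(C(=O)N2N=C(c3ccccc3)CC2c2cn(C)c3ccccc23)cn1` gives 154000 nM in this assay.
- Compound 3 `COc1cccc(C2=NN(C(=O)c3ccc(C)nc3)C(c3cn(C)c4ccc(OC)cc34)C2)c1` gives > 300000 nM in this assay; this too is a limit of the assay.

Among the measured compounds shown here, the only change that recurs in the set is methoxy in place of methyl on an aromatic carbon. Between the two measured compounds it produces an at least 1.9-fold higher number from compound 2 to compound 1 (0.28 log units; that floor lies within the scatter); the step carries a floor rather than a size because the limit of > 300000 nM in this assay, at which 2 of the 3 values shown sit, caps what the assay reports for compound 1.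

Compound 4 `COc1cccc(C2=NN(C(=O)c3ccc(OC)nc3)C(c3cn(C)c4ccc(OC)cc34)C2)c1` has not been measured. For the measured compounds named here, it differs from compound 3 by methoxy in place of methyl on an aromatic carbon, the same change at the same place as the one made from compound 2 to compound 1. How the core of compound 3 differs from that of compound 2 is not broken down here.

The expectation for compound 4 rests on compound 3 already standing at a limit and on the earlier step, an at least 1.9-fold higher number from compound 2 to compound 1 (0.28 log units; that floor lies within the scatter), having moved the number upward rather than downward. Compound 4 is therefore expected to give 300000 nM in this assay, most likely reported again only as a limit. The expected step is a number no higher from compound 3 to compound 4 (the limit leaves the size open).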

Compound 4, half-maximal cytotoxic concentration: > 300000 nM
Compound 4: no number, only a limit; the forecaster's own chance of this, stated with the estimate: 85%; the middle value sits exactly at the limit.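

No step can be read between compound 3 and compound 4 in this assay, because both values are limits of the assay and not numbers: the limit of > 300000 nM in this assay, at which 3 of the 4 values shown sit. The compounds shown leave open how far methoxy in place of methyl moves the number on the core of compound 3, and whether that shift matches the one on the core of compound 2.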